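The source may report more compounds than this note shows. Statements on the series, on what has been measured and on what is new or still open speak of the compounds shown alone.

Measured in a functional assay on U-251 cells (Homo sapiens) for inhibition, read by sulforhodamine B assay, with a stated time of 72 h; on this read-out lower numbers stand for an effect already at smaller amounts and higher numbers for an effect only at larger amounts of compound:
- Compound 1 `CC(C)(C)c1ccc(C(=O)/C=C/c2ccc([N+](=O)[O-])o2)cc1`: 44500 nM
- Compound 2 `CCCCc1ccc(C(=O)/C=C/c2ccc([N+](=O)[O-])o2)cc1`: 3900 nM

Compound 2 holds the lower of these two numbers. Compound 3 `O=C(/C=C/c1ccc([N+](=O)[O-])o1)c1ccc(-n2ccnc2)cc1` carries 1H-imidazol-1-yl in place of butyl on an aromatic carbon. Going by the values given here, only one measured step bears on this change: an 11-fold lower number from compound 1 to compound 2 (1.06 log units; beyond the scatter), which is large and also swaps a group on an aromatic carbon. That step involves no ring group, so it gives no firm direction, but a moderately higher number is expected in this assay. The expected step is a 1.8-fold higher number from compound 2 to compound 3 (0.25 log units; within the scatter). For compound 3 the estimated value is 7000 nM, with an expected range from 1500 nM to 30000 nM.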

Compound 3, half-maximal effective concentration: 22600 nM
For compound 3 the middle estimate is 3.2-fold (0.51 log units) below the measured one, within the range that was stated.
By their numbers in this assay, from the lowest: compound 2; then compounds 3 and 1 (each within the scatter of the next).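

In this assay, putting a ring group at this position for the first time among these compounds, 1H-imidazol-1-yl in place of butyl, gives a 5.8-fold higher number from compound 2 to compound 3 (0.76 log units; beyond the scatter). Against tert-butyl, the same ring gives a 2.0-fold lower number from compound 1 to compound 3 (0.29 log units; within the scatter), so compound 1 and compound 3 cannot be ordered, and butyl in compound 2 keeps the lowest number. No measurement here accounts for these differences. The compounds shown leave open whether a longer chain such as hexyl would go beyond butyl. They also leave open how a phenyl or morpholine ring would compare with 1H-imidazol-1-yl at this position.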